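The source may hold more compounds than are shown below. What is called first, only, known or untested is meant among the compounds shown, and "the series" means these compounds.

Measured so far: compound 1 `O=C(CCCCCCc1ccccc1)c1ncc(-c2ccccc2F)o1`, 110 nM; compound 2 `COc1ccc(-c2cnc(C(=O)CCCCCCc3ccccc3)o2)cc1`, 100 nM; both in an assay (Rattus norvegicus) for inhibition of Fatty-acid amide hydrolase 1 (Homo sapiens); a lower number here means a stronger inhibitor, a higher number a weaker inhibitor.

Compound 2 sits at the lower of the two numbers, with compound 1 within the scatter of it (a 1.1-fold lower number from compound 1 to compound 2 (0.04 log units; within the scatter)). Compound 3 `O=C(CCCCCCc1ccccc1)c1ncc(-c2ccncn2)o1` differs from compound 2 as follows: pyrimidin-4-yl in place of 4-methoxyphenyl on an aromatic carbon. Among the compounds with values here, the only measured step swaps one carbon-only six-membered ring for another and bears on this change only loosely; no measured step brings ring nitrogens in. On that basis the step expected for compound 3 is estimated as a 1.4-fold lower number from compound 2 to compound 3 (0.15 log units; within the scatter), with a wide range around it. For compound 3 the estimate is 70 nM, between 15 nM and 300 nM.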

Compound 3, inhibition constant: 2.3 nM
Compound 3: middle estimate off by 30-fold (1.48 log units), on the high side; measured number below the stated range.
By their numbers in this assay, from the lowest: compound 3; then compounds 2 and 1 (each within the scatter of the next).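

In this assay, the aromatic carbon next to the ring oxygen proves highly sensitive to the ring it carries: pyrimidin-4-yl gives (a 43-fold lower number from compound 2 to compound 3 (1.64 log units; beyond the scatter)) and (a 48-fold lower number from compound 1 to compound 3 (1.68 log units; beyond the scatter)). The step between the two carbon-only rings gave no sign of this, so the large change appears only with a ring holding two nitrogens. No supporting data bear on what lies behind the change.

Still open, on these data alone, is whether both ring nitrogens are needed, which pyridin-2-yl, with a single ring nitrogen, would address. Also open, as far as these compounds go, is whether the pyrimidin-4-yl ring accepts an added group such as a carboxylic acid.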